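This account rests on a few compounds, and the source may have more. Where it says the series, first, only, none or still open, it means among the compounds named here.

Measured compounds:
compound 1 `COc1ccccc1/C=C/C(=O)/C=C/c1ccc(OCc2cn(CCCOc3cc(=O)oc4ccccc34)nn2)c(OC)c1`: "not active" (no number reported)
compound 2 `COc1ccccc1/C=C/C(=O)/C=C/c1ccc(OCc2cn(CCOc3cc(=O)oc4ccccc34)nn2)c(OC)c1`: 11%
compound 3 `COc1ccc(/C=C/C(=O)/C=C/c2ccc(OCc3cn(CCOc4cc(=O)oc5ccccc45)nn3)c(OC)c2)cc1OC`: 19%

In a functional assay on PC-3 cells (Homo sapiens) for inhibition, read by sulforhodamine B assay, with a stated time of 48 h, tested at 50 uM (a higher number here means more inhibition of growth at the concentration tested, a lower number less inhibition of growth), compound 1 is reported only as "not active" (no number reported), so no single number for compound 1 is available, and it stands outside the numbers that compounds 2 and 3 give. In this assay compound 2 gives 11%, and in this assay compound 3 gives 19%.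

The unmeasured compound 4 `COc1ccc(/C=C/C(=O)/C=C/c2ccc(OCc3cn(CCCOc4cc(=O)oc5ccccc45)nn3)c(OC)c2)cc1OC` arises from compound 1 by 3,4-dimethoxyphenyl in place of 2-methoxyphenyl on a double-bonded chain carbon bound to a double-bonded chain carbon. Among the measured compounds shown here, the one measured step that bears on this change is a number 8 percentage points higher from compound 2 to compound 3 (within the scatter), and it lies within the scatter. Compound 2 and compound 3 carry a shorter chain than compound 1 and compound 4, but the change at the double-bonded chain carbon is the same. A step of the same kind is therefore expected in this assay from compound 1 to compound 4: none beyond the scatter, with compound 4 remaining weakly active at most.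

Compound 4 is expected to give about 12% in this assay, with a range from 0% to 25%.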

Compound 4, percent growth inhibition at one concentration: 9%
Compound 4: middle estimate off by 3 percentage points, on the high side, within the range that was stated.
By their numbers in this assay, from the lowest: compounds 4, 2 and 3 (each within the scatter of the next).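

No new step can be read: in this assay compound 1 stands as "not active" (no number reported), so its pair with compound 4, at 9%, gives no size of change. The compounds shown leave open whether the longer chain alters growth inhibition. Nothing shown explains these values.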